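This account rests on a few compounds, and the source may have more. Where it says the series, first, only, none or still open, it means among the compounds named here.

Measured compounds:
- compound 1, `COc1ccc(/C=C2\CCC/C(=C\c3ccccc3[N+](=O)[O-])C2=O)cc1`: 45.1 ug/mL
- compound 2, `COc1cccc(/C=C2\CCC/C(=C\c3ccccc3[N+](=O)[O-])C2=O)c1`: 14.3 ug/mL
- compound 3, `COc1cc(/C=C2\CCC/C(=C\c3ccccc3[N+](=O)[O-])C2=O)cc(Br)c1OC`: 8.99 ug/mL

All three were tested in a functional assay on MDA-MB-231 cells (Homo sapiens) for cytotoxicity, read by MTT assay; a lower number here means a stronger inhibitor, a higher number a weaker inhibitor. Compound 1 gives 45.1 ug/mL, compound 2 gives 14.3 ug/mL, and compound 3 gives 8.99 ug/mL. Among the compounds with values here, the one step between compounds differing in a single place is a 3.2-fold lower number from compound 1 to compound 2 (0.50 log units; beyond the scatter). Compound 3 has the lowest of the three numbers; compound 2 lies within the scatter of it, while compound 1 sits beyond the scatter above it.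

Compound 4, `CCCOc1c(Br)cc(/C=C2\CCC/C(=C\c3ccccc3[N+](=O)[O-])C2=O)cc1OC`, differs from compound 3 by ethyl in place of hydrogen on a saturated chain carbon bound to an oxygen on an aromatic ring; seen one bond further out, methoxy becomes propoxy. Within the data shown here, no measured step touches this part of the molecule: the only known step moves a methoxy group around a ring rather than lengthening it. There is therefore no basis for expecting a shift in this assay beyond the scatter in either direction. The estimated step from compound 3 to compound 4 is a 1.0-fold higher number from compound 3 to compound 4 (0.00 log units; within the scatter). Compound 4 is thus expected to give about 9 ug/mL, between 3 ug/mL and 27 ug/mL.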

Compound 4, half-maximal inhibitory concentration: 1.99 ug/mL
Compound 4: middle estimate off by 4.5-fold (0.66 log units), on the high side; measured number outside the range, below it.
By their numbers in this assay, from the lowest: compound 4; then compounds 3 and 2 (each within the scatter of the next); then compound 1.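

Read in this assay, on a saturated chain carbon bound to an oxygen on an aromatic ring, the change from methoxy to propoxy gives a 4.5-fold lower number from compound 3 to compound 4 (0.65 log units; beyond the scatter) at a place the earlier compounds left untouched. Within the data shown here, the only earlier step moved a methoxy group around a ring, whereas this one shows that lengthening the group while it stays in the same place also shifts the number, and that here the larger group lowers it rather than raises it. No measurement is available that explains this shift.

On these data alone, one pair cannot define a trend, so it remains open whether ethoxy would fall on the way to this result or whether butoxy, a longer chain, would lower the number further or reverse the change. Also open, as far as these compounds go, is how an amine or a carboxylic acid at the end of this chain would read.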